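An aryl swap on a sulfonyl sulfur

The compounds below may be only part of what the source reports. "The series", "measured", "known", "first", "only" and "open" are said of these compounds alone.

Of the compounds shown here, two have been measured so far in a functional assay on VCaP cells (Homo sapiens) for antiproliferative activity, read by propidium iodide staining, with a stated time of 96 h (on this read-out lower numbers stand for stronger inhibition and higher numbers for weaker inhibition), and they read as follows.
compound 1 `CC(O)(CS(=O)(=O)c1cccc(OC(F)(F)F)c1)C(=O)Nc1ccc(S(F)(F)(F)(F)F)cc1` gives 23700 nM
compound 2 `CC(O)(CS(=O)(=O)c1ccc(F)cc1)C(=O)Nc1cccc(S(F)(F)(F)(F)F)c1` gives 37900 nM

Compound 2 at 37900 nM and compound 1 at 23700 nM lie within the usual scatter of each other and cannot be told apart in this assay on these numbers.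

The next compound, compound 3 `CC(O)(CS(=O)(=O)c1ccccc1OC(F)(F)F)C(=O)Nc1cccc(S(F)(F)(F)(F)F)c1` has not yet been measured. It comes from compound 2 through a single change, 2-(trifluoromethoxy)phenyl in place of 4-fluorophenyl on a sulfonyl sulfur and everything else stays the same. Going by the values given here, no measured pair isolates a change of this kind, so there is no direct step to lean on. Among the compounds with values here, the only guide is the narrow span set by compound 1 at 23700 nM and compound 2 at 37900 nM in this assay and little movement is expected from it. If anything, a slightly lower number is expected, with nothing beyond the scatter. The expected move is a 1.4-fold lower number from compound 2 to compound 3 (0.13 log units; within the scatter) and it is estimated to stay inside the scatter. For compound 3 the estimated value is 28000 nM with 11000 nM to 60000 nM as the expected range.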

Compound 3, half-maximal inhibitory concentration: 13900 nM
Compound 3: middle estimate off by 2.0-fold (0.30 log units), on the high side; low and high end bracket the measured number.
By their numbers in this assay, from the lowest: compounds 3, 1 and 2 (each within the scatter of the next, the first and the last beyond it).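

In this assay, 2-(trifluoromethoxy)phenyl in place of 4-fluorophenyl on a sulfonyl sulfur gives a 2.7-fold lower number from compound 2 to compound 3 (0.44 log units; beyond the scatter), a modest step and the first in this set to isolate a change in one place. It shows that the aryl group on this sulfur can shift the read-out beyond the scatter while the rest of the molecule stays the same, something the earlier pair could not show, since compound 1 and compound 2 differ in more than one place. Nothing available bears on why the number falls with this swap, so the step stands as an observation without an assigned cause.

The single step replaces one substituted aryl group with another, changing both the substituent and its printed ring position, so the compounds shown cannot separate the contribution of the trifluoromethoxy group from that of its location. Going by these compounds, how an unsubstituted phenyl, or a ring carrying a methoxy group or a nitrile, would read at this sulfonyl sulfur remains open, as does whether the same swap would give a step of similar size on another core.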